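Replacing an Aryl Amide with an Indoline Amide

The source may hold more compounds than are shown below. What is called first, only, known or untested is meant among the compounds shown, and "the series" means these compounds.

Compound 1 is `Cc1cccc(C)c1NC(=O)CSc1nnc(-c2ccoc2C)n1Cc1ccco1` and gives > 15800 nM in a functional assay on CHO cells for antagonist activity at Orexin/Hypocretin receptor type 1 (Homo sapiens), read by FLIPR and calcium flux (on this read-out higher numbers stand for weaker inhibition and lower numbers for stronger inhibition), which is a limit of the assay rather than a number (the limit of > 15800 nM in this assay, at which 1 of the 3 values shown sits). Compound 2 is `Cc1cccc(NC(=O)CSc2nnc(-c3ccoc3C)n2Cc2ccco2)c1` and gives 2510 nM. Compound 3 is `CC(=O)c1ccc(NC(=O)CSc2nnc(-c3ccoc3C)n2Cc2ccco2)cc1` and gives 2510 nM.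

Compound 3 stands level with compound 2 (no change at the digits printed from compound 2 to compound 3 (within the scatter)). Changing the group on the amide-type nitrogen away from 2,6-dimethylphenyl gave beyond-scatter steps in both measured cases (an at least 6.2-fold lower number from compound 1 to compound 2 (0.79 log units; beyond the scatter) and an at least 6.2-fold lower number from compound 1 to compound 3 (0.79 log units; beyond the scatter)), while the exchange of 3-methylphenyl for 4-acetylphenyl stayed within the scatter.

Compound 4 is `Cc1occc1-c1nnc(SCC(=O)NN2CCc3ccccc32)n1Cc1ccco1`. The change is 2,3-dihydro-1H-indol-1-yl in place of 4-acetylphenyl on an amide-type nitrogen. Here the ring is joined to the amide-type nitrogen through its own nitrogen, and no measured step covers that kind of exchange, so the evidence is thin. The expected step of a 2.0-fold higher number from compound 3 to compound 4 (0.30 log units; within the scatter) is small, with wide uncertainty. Compound 4 is therefore estimated at 5000 nM, within 1000 nM to 25000 nM.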

Compound 4, inhibition constant: > 15800 nM
Compound 4: no number, only a limit (the forecaster's own chance of this, stated with the estimate: 30%); middle value at least 3.1-fold (0.49 log units) from the limit.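

In this assay, 2,3-dihydro-1H-indol-1-yl does not hold the level of the two aryl groups, since higher numbers mean weaker inhibition: an at least 6.2-fold higher number from compound 3 to compound 4 (0.79 log units; beyond the scatter), and an at least 6.2-fold higher number from compound 2 to compound 4 (0.79 log units; beyond the scatter). The earlier compounds shown here showed a drop only for 2,6-dimethylphenyl, so this second drop shows that activity at this amide-type nitrogen also depends on other groups, here one joined through its own nitrogen. Compound 4 gives > 15800 nM, which is a limit of the assay and not a number, and the step between compound 1 and compound 4 cannot be read: the limit of > 15800 nM in this assay, at which 2 of the 4 values shown sit.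

The compounds shown leave open whether the link through the ring nitrogen or the fused ring itself goes with the drop. Also open, from the compounds shown here alone, is how a piperidin-1-yl group or a 4-carboxyphenyl group would behave on this nitrogen.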